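Hydroxyethyl ether in a naphthoquinone series

This account rests on a few compounds, and the source may have more. Where it says the series, first, only, none or still open, it means among the compounds named here.

Compound 1 `COCCO[C@H](CC=C(C)C)C1=CC(=O)c2c(O)ccc(O)c2C1=O` gives 43200 nM in a functional assay on DU-145 cells (Homo sapiens) for cytotoxicity, read by MTT assay (on this read-out lower numbers stand for stronger inhibition and higher numbers for weaker inhibition), the highest of the two numbers recorded. Compound 2 `CC(C)=CC[C@@H](OC(=O)CC(O)c1ccccc1)C1=CC(=O)c2c(O)ccc(O)c2C1=O` gives 17000 nM in this assay, a lower number beyond the scatter. Compound 3 `CC(C)=CC[C@@H](OCCO)C1=CC(=O)c2c(O)ccc(O)c2C1=O` differs from compound 1 by hydrogen in place of methyl on an oxygen on a saturated carbon, methoxy to hydroxy on the 2-methoxyethyl side chain. Among the compounds with values here, no measured pair shows this change, so the direction is open. The step of a 1.2-fold lower number from compound 1 to compound 3 (0.09 log units; within the scatter) is expected to stay within the scatter, with no clear direction. Compound 3 is estimated at 35000 nM, with a range from 12000 nM to 100000 nM.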

Compound 3, half-maximal inhibitory concentration: 9900 nM
Compound 3: middle estimate off by 3.5-fold (0.55 log units), on the high side, and the stated range ends above it.
By their numbers in this assay, from the lowest: compounds 3 and 2 (each within the scatter of the next); then compound 1.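

In this assay, methoxy to hydroxy on the 2-methoxyethyl side chain gives a 4.4-fold lower number from compound 1 to compound 3 (0.64 log units; beyond the scatter). Within the data shown here, this is the first one-place step, and it shows that the read-out responds to a change as small as one methyl on this oxygen. Nothing available accounts for the step.

As far as these compounds go, it remains open whether the hydroxy itself matters, as a single pair cannot separate that from the loss of the methyl. A 2-aminoethyl chain, a carboxylic acid or a longer 3-hydroxypropyl chain at this place would test how far the step extends.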